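The source may hold more compounds than are shown below. What is called first, only, known or untested is meant among the compounds shown, and "the series" means these compounds.

Compound 1, `O=C(COc1ccc2cc(/C=C3/SC(=O)NC3=O)ccc2c1)Nc1ccccn1`, gives 17000 nM in an assay on isolated protein for inhibition of histone deacetylase 4 (Homo sapiens), with a stated time of 1 h; a lower number here means a stronger inhibitor, a higher number a weaker inhibitor.
Compound 2, `O=C(COc1ccc2cc(/C=C3/SC(=O)NC3=O)ccc2c1)Nc1ccc(F)cc1`, gives 1600 nM in this assay.
Compound 3, `O=C(COc1ccc2cc(/C=C3/SC(=O)NC3=O)ccc2c1)Nc1c(F)cc(F)cc1Br`, gives 1100 nM in this assay.

All three share the same core and differ only in the group on the amide-type nitrogen. Compound 1 has the highest number of the three, meaning the weakest inhibition: an 11-fold lower number from compound 1 to compound 2 (1.03 log units; beyond the scatter) and a 15-fold lower number from compound 1 to compound 3 (1.19 log units; beyond the scatter). Between the two phenyl-bearing compounds the gap is small, a 1.5-fold lower number from compound 2 to compound 3 (0.16 log units; within the scatter), so compounds 2 and 3 cannot be told apart here.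

Compound 4, `Cc1ccc(NC(=O)COc2ccc3cc(/C=C4/SC(=O)NC4=O)ccc3c2)cc1Cl`, has not yet been measured in this assay. Relative to compound 1 the change is 3-chloro-4-methylphenyl in place of pyridin-2-yl on an amide-type nitrogen. The two measured steps from compound 1 both replace pyridin-2-yl with a carbon-only aromatic ring carrying halogens, and both give large drops in the number. The 3-chloro-4-methylphenyl group is again a carbon-only ring with a halogen, so a drop of similar size is expected: a 13-fold lower number from compound 1 to compound 4 (1.12 log units; beyond the scatter). Compound 4 is therefore estimated at 1300 nM, with a likely range from 450 nM to 4000 nM.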

Compound 4, half-maximal inhibitory concentration: 1100 nM
Compound 4: the middle estimate sits 1.2-fold (0.07 log units) above what was measured; measured number inside the range.
By their numbers in this assay, from the lowest: compounds 3, 4 and 2 (each within the scatter of the next); then compound 1.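

Replacing pyridin-2-yl with 3-chloro-4-methylphenyl gives a 15-fold lower number from compound 1 to compound 4 (1.19 log units; beyond the scatter) in this assay and so a third ring of carbon only stands clearly apart from compound 1, this time with a methyl group on the ring as well as a halogen. The new ring cannot be told apart from the other two carbon-only rings, with no change at the digits printed from compound 3 to compound 4 (within the scatter) and a 1.5-fold lower number from compound 2 to compound 4 (0.16 log units; within the scatter) so the differences in halogen and methyl group among these three do not show in the number. Nothing measured here explains these results.

The compounds shown leave open how a plain phenyl group without any halogen would read, which would help separate the loss of the ring nitrogen from the gain of a halogen. They also leave open what a cyclohexyl group, or a phenyl ring carrying a carboxylic acid, would do on this nitrogen.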